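From Compound 2 to Compound 3: a Ring Exchange

The compounds below may be only part of what the source reports. "The series", "measured", "known", "first", "only" and "open" are said of these compounds alone.

Of the compounds shown here, two have been tested so far. Compound 1 `COc1cc2c(Oc3ccc(NC(=O)c4c(C)n(C)n(-c5ccccc5)c4=O)cc3F)ccnc2cc1OCCCN1CCN(C)CC1` gives 1240 nM in a functional assay on A549 cells (Homo sapiens) for cytotoxicity, read by MTT assay, with a stated time of 48 h; on this read-out lower numbers stand for stronger inhibition and higher numbers for weaker inhibition. Compound 2 `COc1cc2c(Oc3ccc(NS(=O)(=O)c4cccc(-c5cnn(C)c5)c4)cc3F)ccnc2cc1OCCCN1CCN(C)CC1` gives 8850 nM in this assay, the higher of the two numbers and thus the weaker inhibitor of the pair. Compound 3 `COc1cc2c(Oc3ccc(NS(=O)(=O)c4cccc(-c5ccsc5)c4)cc3F)ccnc2cc1OCCCN1CCN(C)CC1` is not yet measured; it differs from compound 2 by thiophen-3-yl in place of 1-methyl-1H-pyrazol-4-yl on an aromatic carbon. Going by the values given here, no measured pair shows what this exchange does here, so a step no larger than the usual scatter is expected, in either direction. The expected step from compound 2 to compound 3 is a 1.0-fold higher number from compound 2 to compound 3 (0.01 log units; within the scatter). Compound 3 is therefore estimated at 9000 nM, within 3000 nM to 27000 nM.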

Compound 3, half-maximal inhibitory concentration: 4760 nM
Beside the measured number, compound 3's estimate is 1.9-fold (0.28 log units) above it; the range from low to high includes it.
By their numbers in this assay, from the lowest: compound 1; then compounds 3 and 2 (each within the scatter of the next).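

Going by these compounds alone, the first measured exchange at this place, on an aromatic carbon of a six-membered aromatic ring of carbon only, puts thiophen-3-yl in place of 1-methyl-1H-pyrazol-4-yl and gives a 1.9-fold lower number from compound 2 to compound 3 (0.27 log units; within the scatter) in this assay for this pair. These two five-membered aromatic rings therefore cannot be told apart in this measurement. No measurement of any property of these groups bears on this result. Still open, going by these compounds, is whether a group other than a five-membered aromatic ring at this place, such as an amine or a carboxylic acid, would give a step beyond the scatter.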